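Compound 2 to Compound 3: Same Atoms, Joined Differently

The source may hold more compounds than are shown below. What is called first, only, known or untested is meant among the compounds shown, and "the series" means these compounds.

Measured in a physicochemical assay for lipophilicity, at pH 7.4; a higher number here means a more lipophilic compound, a lower number a more polar compound:
- Compound 1 `Cc1cc(C)c(CN2CCc3c(Cl)cc([C@H](CO)[C@H]4CCCO4)c(Cl)c3C2=O)c(=O)[nH]1`: 2.1
- Compound 2 `Cc1cc(C)c(CN2CCc3c(Cl)cc([C@H](CO)[C@@H]4CCCO4)c(Cl)c3C2=O)c(=O)[nH]1`: 2.4

For the measured compounds named here, of these two compounds, compound 2 stands within the scatter of its only neighbour, compound 1. The next structure, compound 3 `Cc1cc(C)c(CN2CCc3c(Cl)cc([C@@H](CO)[C@@H]4CCOC4)c(Cl)c3C2=O)c(=O)[nH]1`, has the same atoms as compound 2, joined differently: a group of 8 heavy atoms (6 carbon, 2 oxygen; one five-membered non-aromatic ring with 1 hetero atom) in place of a group of 8 heavy atoms (6 carbon, 2 oxygen; one five-membered non-aromatic ring with 1 hetero atom), on an aromatic carbon. Going by the values given here, only one measured step exists, a number 0.30 log units higher from compound 1 to compound 2 (within the scatter), and it rests on (the fact that compounds 1 and 2 differ only in the configuration as drawn). It therefore bears only loosely on this change, which alters how the group on the aromatic carbon is joined and not merely its drawn configuration. Among the compounds with values here, with so small a step as the sole guide, no shift beyond the scatter is expected in this assay. The expected change is a number 0.20 log units lower from compound 2 to compound 3 (within the scatter). For compound 3 the estimated value is 2.2, with an expected range from 1.8 to 2.6.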

Compound 3, distribution coefficient: 2
Beside the measured number, compound 3's estimate is 0.20 log units above it; the range from low to high includes it.
By their numbers in this assay, from the lowest: compounds 3, 1 and 2 (each within the scatter of the next, the first and the last beyond it).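

In this assay, for the compounds shown here, rejoining the group on the aromatic carbon produces the first step in this set that lies beyond the scatter: a number 0.40 log units lower from compound 2 to compound 3 (beyond the scatter). The same kind of change read from the other stereoisomer gives a number 0.10 log units lower from compound 1 to compound 3 (within the scatter), so a rearrangement that keeps the same atoms, the same hydrogen-bond donor and acceptor counts and a five-membered ring can move the number beyond the scatter at this position, but does not do so from every starting compound. Nothing known about these compounds accounts for the size of either step.

The compounds shown leave open how much of the shift belongs to the new ring connection and how much to the drawn configuration of the two stereocentres. They also leave open how this assay would respond to a different kind of group on this aromatic carbon, such as an amine or a carboxylic acid.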